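Piperidin-1-yl for azepan-1-yl in the long-chain compound

The source may report more compounds than this note shows. Statements on the series, on what has been measured and on what is new or still open speak of the compounds shown alone.

Compound 1 (`CCCCCCCCCCCCCCCCOP(=O)(O)OCCSC(=S)N1CCCCCC1`) is reported in an ADME assay on HEK293 cells (Homo sapiens) for inhibition, read by MTT assay, with stated times of 18 h and 4 h (a lower number here means a stronger inhibitor, a higher number a weaker inhibitor), only as a limit, > 100000 nM. Compound 1 thus stands at the limit of > 100000 nM in this assay, at which 1 of the 3 values shown sits. The two shorter-chain analogues give numbers: compound 2 (`CCCCCCCCCCOP(=O)(O)OCCSC(=S)N1CCCCCC1`) reads 70000 nM. Compound 3 (`CCCCCCOP(=O)(O)OCCSC(=S)N1CCCCCC1`) reads 70500 nM.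

The next structure, compound 4 (`CCCCCCCCCCCCCCCCOP(=O)(O)OCCSC(=S)N1CCCCC1`), keeps the chain of compound 1 and changes the ring: piperidin-1-yl in place of azepan-1-yl on a thiocarbonyl carbon. In words, piperidin-1-yl stands in place of azepan-1-yl on a thiocarbonyl carbon.

Among the compounds with values here, no measured step changes that group. The nearest evidence is the three chain steps: an at least 1.4-fold lower number from compound 1 to compound 2 (0.15 log units; that floor lies within the scatter), an at least 1.4-fold lower number from compound 1 to compound 3 (0.15 log units; that floor lies within the scatter) and a 1.0-fold higher number from compound 2 to compound 3 (0.00 log units; within the scatter). All three stay within the scatter, so they give no sign of a large response in this assay, though they do not test the ring change itself. No step beyond the scatter is therefore expected, and a second report as a limit is about as likely as a number. The estimated change is an at least 1.1-fold lower number from compound 1 to compound 4 (0.04 log units; that floor lies within the scatter). For compound 4 the expected value is 90000 nM, with an estimated range of 40000 nM to 200000 nM.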

Compound 4, half-maximal inhibitory concentration: > 100000 nM
Compound 4: no number, only a limit; the forecaster's own chance of this, stated with the estimate: 50%; middle value at least 1.1-fold (0.04 log units) away from the limit.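

Compound 1 and compound 4 are both reported only as limits in this assay, so the step from azepan-1-yl to piperidin-1-yl cannot be read: the limit of > 100000 nM in this assay, at which 2 of the 4 values shown sit. The compounds shown leave open whether piperidin-1-yl and azepan-1-yl differ in this assay on any chain.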